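A few compounds are considered here, and "the series" means these few. Any claim that something is new, unique, unknown or untested is made for them only; others in the source may bear on it.

Compound 1 `O=C(Nc1cccc(-c2oc3cc(-c4ccc(F)cc4)ccc3c(=O)c2O)c1)c1ccccc1F` gives 10100 nM
Compound 2 `O=C(Nc1cccc(-c2oc3cc(-c4ccc(F)cc4)ccc3c(=O)c2O)c1)c1cccc(F)c1` gives 15500 nM
Compound 3 `Cc1cc(C(=O)Nc2cccc(-c3oc4cc(-c5ccc(F)cc5)ccc4c(=O)c3O)c2)ccc1F` gives 9540 nM

These three were tested in a functional assay on HepG2 cells (Homo sapiens) for antiproliferative activity, read by CCK-8 assay, with a stated time of 72 h; a lower number here means a stronger inhibitor, a higher number a weaker inhibitor. Compound 1 stands second highest of the three; compound 3 lies nearest to it, with a 1.1-fold lower number from compound 1 to compound 3 (0.02 log units; within the scatter), and compound 2 furthest, with a 1.5-fold higher number from compound 1 to compound 2 (0.19 log units; within the scatter), both within the scatter. Compound 4 `Cc1cc(C)cc(C(=O)Nc2cccc(-c3oc4cc(-c5ccc(F)cc5)ccc4c(=O)c3O)c2)c1` is not yet measured. Against compound 1 it carries 3,5-dimethylphenyl in place of 2-fluorophenyl on a carbonyl carbon. For the measured compounds named here, the steps that bear on this are the two just named, which exchange the aryl group on the carbonyl carbon, together with a 1.6-fold lower number from compound 2 to compound 3 (0.21 log units; within the scatter); none of them moved beyond the scatter. Compound 4 is therefore expected to show no step beyond the scatter, a 1.0-fold higher number from compound 1 to compound 4 (0.02 log units; within the scatter). The estimate for compound 4 is 10500 nM, ranging from 4500 nM to 25000 nM.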

Compound 4, half-maximal inhibitory concentration: 13400 nM
The estimate for compound 4 lay 1.3-fold (0.11 log units) below the measured number; the range from low to high includes it.
By their numbers in this assay, from the lowest: compounds 3, 1, 4 and 2 (each within the scatter of the next).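

In this assay, for the compounds shown here, 3,5-dimethylphenyl on the carbonyl carbon, the first group here without fluorine, stays within the scatter of all three fluorinated compounds (a 1.3-fold higher number from compound 1 to compound 4 (0.12 log units; within the scatter); a 1.4-fold higher number from compound 3 to compound 4 (0.15 log units; within the scatter); a 1.2-fold lower number from compound 2 to compound 4 (0.06 log units; within the scatter)). Among these four compounds, then, fluorine on this phenyl ring is not required for a number in this range, and two methyl groups give a comparable result. Nothing measured here offers a reason for this flat response. Going by these compounds, it remains open whether any group at this place can move the number beyond the scatter, for example a ring bearing an amine or a carboxylic acid, or a saturated ring such as cyclohexyl in place of the phenyl ring.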